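Replacing a methoxyphenyl sulfonamide with a methylthiophene

The compounds below may be only part of what the source reports. "The series", "measured", "known", "first", "only" and "open" are said of these compounds alone.

Measured compounds:
compound 1, `CCN(Cc1ccccc1)C(=O)C1CCN(S(=O)(=O)c2ccc(OC)cc2)CC1`, 84%
compound 2, `CCN(Cc1ccccc1)C(=O)C1CCN(S(=O)(=O)c2cccc(OC)c2)CC1`, 77%
compound 3, `CCN(Cc1ccccc1)C(=O)C1CCN(S(=O)(=O)c2cccc3c2OCCO3)CC1`, 53%

In a functional assay on CHO cells for positive allosteric modulation of muscarinic acetylcholine receptor M5 (Homo sapiens), read by calcium flux (on this read-out higher numbers stand for larger maximal responses and lower numbers for smaller maximal responses), compound 2 gives 77%, the second highest of the three numbers; its nearest neighbour is compound 1 at 84%, with a number 7 percentage points lower from compound 1 to compound 2 (within the scatter), while compound 3 at 53% lies furthest away, with a number 24 percentage points lower from compound 2 to compound 3 (beyond the scatter).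

Compound 4, `CCN(Cc1ccccc1)C(=O)C1CCN(S(=O)(=O)c2ccc(C)s2)CC1`, differs from compound 2 in one place: 5-methylthiophen-2-yl in place of 3-methoxyphenyl on a sulfonyl sulfur.

Going by the values given here, no measured step swaps a benzene ring for a thiophene on the sulfonyl sulfur, so the bearing of the two known steps is indirect. Both change the group on that sulfur; one stays within the scatter and the other gives a modest fall. A decrease of similar or smaller size is therefore expected, a number 9 percentage points lower from compound 2 to compound 4 (within the scatter). Compound 4 is estimated at 68%, in a range from 50% to 86%.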

Compound 4, largest response reached (reported as percent of maximum), in percent of the reference or control that the assay uses: 64%
Beside the measured number, compound 4's estimate is 4 percentage points above it; the measured number falls inside the stated range.
By their numbers in this assay, from the lowest: compound 3; then compound 4; then compounds 2 and 1 (each within the scatter of the next).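

In this assay the 5-methylthiophen-2-yl group on the sulfonyl sulfur loses response against both methoxyphenyl groups, with a number 13 percentage points lower from compound 2 to compound 4 (beyond the scatter) and a number 20 percentage points lower from compound 1 to compound 4 (beyond the scatter) in this change. It still holds more response than the 2,3-dihydro-1,4-benzodioxin-5-yl group, with a number 11 percentage points higher from compound 3 to compound 4 (beyond the scatter) on that swap, so a benzene ring is not required at this position for a sizeable maximal response. Nothing available explains these differences. On these data alone, what the methyl group on the thiophene contributes remains open, as does how a 5-chlorothiophen-2-yl or a 3-aminophenyl group would read out here.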